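The compounds below may be only part of what the source reports. "The series", "measured", "known", "first", "only" and "open" are said of these compounds alone.

In a functional assay on A549 cells (Homo sapiens) for cytotoxicity, read by MTT assay, with a stated time of 6 days (on this read-out higher numbers stand for an effect only at larger amounts of compound and lower numbers for an effect already at smaller amounts), three compounds have been measured, and each entry is a limit of the assay, not a number:

compound 1 `COC(=O)c1c(-c2cc(OC)cc(OC)c2)oc2ccccc2c1=O`: > 25 ug/mL
compound 2 `COC(=O)c1c(-c2ccc([N+](=O)[O-])cc2)oc2ccccc2c1=O`: > 25 ug/mL
compound 3 `COC(=O)c1c(-c2ccc([N+](=O)[O-])cc2)oc2cc(OC)ccc2c1=O`: > 25 ug/mL

Compound 2 therefore stands only at a limit, > 25 ug/mL, with no number to serve as a starting point. The two further results offer no firmer reference, since they are limits as well.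

The step of interest leads to compound 4 `COC(=O)c1c(-c2ccc(OCc3ccccc3)cc2)oc2ccccc2c1=O`, with benzyloxy in place of nitro on an aromatic carbon.

Going by the values given here, the only measured single-place step is a step that the two limits leave unreadable from compound 2 to compound 3. That step puts methoxy in place of hydrogen on an aromatic carbon, a different change, and it offers no size to carry over. The whole of the evidence is the limit of > 25 ug/mL in this assay, at which 3 of the 3 values shown sit. Among the compounds with values here, no measured step therefore bears directly on the exchange of nitro for benzyloxy, and no shift beyond the scatter is expected in this assay, in either direction. Compound 4 is thus expected most likely to report only a limit as well.

The expected step, which is an estimate only, is a number no higher from compound 2 to compound 4 (the limit leaves the size open).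

For compound 4 the estimated value is 25 ug/mL, with an expected range from 10 ug/mL to 50 ug/mL.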

Compound 4, concentration for half-maximal effect: > 25 ug/mL
Compound 4 gave a limit, no number (the forecaster's own chance of this, stated with the estimate: 75%); the middle value sits exactly at the limit.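

In this assay compound 4 gives > 25 ug/mL, which is a limit and not a number. Going by these compounds alone, compound 2 is also known only as a limit, so no step from compound 2 to compound 4 can be read. The compounds shown leave open where any of them reaches its half-maximal effect, and whether any change in structure shifts it: the limit of > 25 ug/mL in this assay, at which 4 of the 4 values shown sit.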